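A few compounds are considered here, and "the series" means these few. Any claim that something is new, unique, unknown or untested is made for them only; others in the source may bear on it.

Of the compounds shown here, three sharing one core have been tested in an ADME assay on LL24 cells (Homo sapiens) for inhibition, read by MTT assay, with a stated time of 24 h; a higher number here means a weaker inhibitor, a lower number a stronger inhibitor. Compound 1 `O=C(N/N=C/c1ccc([N+](=O)[O-])o1)c1ccccc1Oc1ccccc1` gives a limit rather than a number, > 200000 nM. Compound 2 `CC(C)(C)c1ccc(C(=O)N/N=C/c2ccc([N+](=O)[O-])o2)cc1` likewise returns only a limit, > 200000 nM. Compound 3 `Cc1cccc(C(=O)N/N=C/c2ccc([N+](=O)[O-])o2)c1` also gives a limit, > 200000 nM. Compound 2 therefore stands nowhere in particular on the numbers shown: it sits at the same limit as the two others, all three resting at the limit of > 200000 nM in this assay, at which 3 of the 3 values shown sit, so none of the three can be placed above or below another in this assay.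

Compound 4 `O=C(N/N=C/c1ccc([N+](=O)[O-])o1)c1ccc(Cl)cc1` has not yet been measured in this assay. It differs from compound 2 in one place: chloro in place of tert-butyl on an aromatic carbon. For the measured compounds named here, with every measured value in this assay resting at the limit of > 200000 nM in this assay, at which 3 of the 3 values shown sit, no step between measured compounds is available to show what such a change does here. The step from compound 2 to compound 4 in this assay is expected to be none beyond the scatter, that is a step that the limit leaves unreadable from compound 2 to compound 4. Compound 4 is accordingly estimated to give 250000 nM in this assay, within a range from 100000 nM to 600000 nM, and is expected most likely to come back as a limit once more rather than as a number.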

Compound 4, half-maximal inhibitory concentration: 187000 nM
Beside the measured number, compound 4's estimate is 1.3-fold (0.13 log units) above it; low and high end bracket the measured number.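

In this assay, compound 4 is the only one of the four compounds shown to return a number rather than a limit, 187000 nM. Compound 2, by contrast, gives only a limit, > 200000 nM. Chloro in place of tert-butyl on an aromatic carbon, para to a large group, therefore yields a step that can at last be partly read, an at least 1.0-fold lower number from compound 2 to compound 4 (0.02 log units; that floor lies within the scatter), so the data show that a number can be reached with chloro at this position but do not show that the change itself moves the result beyond the scatter.

On these data alone, the true distance between compound 2 and compound 4 stays unknown, and so does whether an amine, a carboxylic acid or a longer chain on this aromatic carbon would give a number, or one clearly apart from that of compound 4. Any other step in this set cannot be read, and most of what is shown still rests at a single value that is not a number: the limit of > 200000 nM in this assay, at which 3 of the 4 values shown sit.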